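A few compounds are considered here, and "the series" means these few. Any claim that something is new, unique, unknown or untested is made for them only; others in the source may bear on it.

Of the compounds shown here, two have been measured so far. Compound 1 `COc1cc(C2=NOC(c3c[nH]c4ccccc34)C2)cc(OC)c1OC` carries a trimethoxyphenyl group on one side of the shared core and an indole on the other; in a functional assay on PC-3 cells (Homo sapiens) for inhibition, read by MTT assay, with a stated time of 48 h (on this read-out higher numbers stand for weaker inhibition and lower numbers for stronger inhibition), compound 1 gives 15500 nM. Compound 2 `Cc1[nH]c2ccccc2c1C1CC(c2ccncc2)=NO1` replaces the trimethoxyphenyl with a pyridine and carries a methyl on the indole; in this assay compound 2 gives 21200 nM. On the numbers shown, compound 2 stands alongside compound 1: the two values lie within the usual scatter of each other, so nothing separates them, and both describe weak inhibition of these cells.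

Compound 3 `c1ccc2c(C3CC(c4ccncc4)=NO3)c[nH]c2c1` is the next candidate. It differs from compound 2 in one place: hydrogen in place of methyl on an aromatic carbon. For the measured compounds named here, no measured pair in this set shows what such a removal does on its own, so the expectation rests only on the weak activity of compound 2 itself. The step from compound 2 to compound 3 is expected to be small, a 1.1-fold lower number from compound 2 to compound 3 (0.03 log units; within the scatter), with no clear direction beyond the scatter. Compound 3 is therefore estimated at 20000 nM, within a range from 7000 nM to 60000 nM.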

Compound 3, half-maximal inhibitory concentration: > 100000 nM
Compound 3 ended at the assay's limit; the forecaster's own chance of this, stated with the estimate: 15%; at least 5.0-fold (0.69 log units) between middle value and limit.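

Taking away one methyl, from an aromatic carbon of the five-membered ring next to the ring nitrogen, is the first change in this series whose effect can be read in this assay, and it is not a silent one: the step is an at least 4.7-fold higher number from compound 2 to compound 3 (0.67 log units; beyond the scatter). In this pair, compound 2 with the methyl gives a measurable value, while compound 3 with hydrogen in its place does not, so a single carbon at this position can matter in this assay. For compound 3, > 100000 nM is a limit of the assay and not a number, so the step gives only a minimum size because of where that limit lies: the limit of > 100000 nM in this assay, at which 1 of the 3 values shown sits.

From the compounds shown here alone, compound 1 carries hydrogen at this same place alongside its trimethoxyphenyl group and gives 15500 nM, so the need for a methyl cannot be taken as general, and what a methyl would do in that setting stays open. Going by these compounds, it also stays open whether an ethyl group or a chlorine atom at this place would act as the methyl does, or whether only the methyl gives this result.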